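From 4-methylphenyl to 2-hydroxyphenyl on a shared core

A few compounds are considered here, and "the series" means these few. Any claim that something is new, unique, unknown or untested is made for them only; others in the source may bear on it.

Measured in a functional assay for inhibition, with Homo sapiens as the target; a higher number here means weaker binding, a lower number tighter binding:
compound 1 `CC(C)(Oc1ccccc1)C1OCC(C/C=C\CCC(=O)O)C(c2cccnc2)O1`: 75.9 nM
compound 2 `COc1ccc(OC(C)(C)C2OCC(C/C=C\CCC(=O)O)C(c3cccnc3)O2)cc1`: 302 nM
compound 3 `Cc1ccc(OC(C)(C)C2OCC(C/C=C\CCC(=O)O)C(c3cccnc3)O2)cc1`: 631 nM

Of the three, compound 3 has the highest number, 631 nM, and so binds least tightly. It lies a 2.1-fold higher number from compound 2 to compound 3 (0.32 log units; beyond the scatter) and an 8.3-fold higher number from compound 1 to compound 3 (0.92 log units; beyond the scatter), both beyond the scatter. The next compound to be measured is compound 4 `CC(C)(Oc1ccccc1O)C1OCC(C/C=C\CCC(=O)O)C(c2cccnc2)O1`, and the change leading to it is 2-hydroxyphenyl in place of 4-methylphenyl on an oxygen on a saturated carbon.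

Within the data shown here, two measured steps bear most directly on this change. Adding a substituent to the unsubstituted ring raised the number both times: a 4.0-fold higher number from compound 1 to compound 2 (0.60 log units; beyond the scatter) with methoxy, and an 8.3-fold higher number from compound 1 to compound 3 (0.92 log units; beyond the scatter) with methyl. Compound 4 loses the 4-methylphenyl group, which points back towards compound 1 at 75.9 nM. However, no measured compound carries a 2-hydroxyphenyl group, so its own contribution is unknown, and the full return to compound 1 is not assumed. A modest move to a lower number is therefore expected, smaller than the step that separates compound 1 from compound 3. The estimated step is a 4.2-fold lower number from compound 3 to compound 4 (0.62 log units; beyond the scatter). For compound 4 the estimated value is 150 nM, with an expected range of 35 nM to 600 nM.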

Compound 4, dissociation constant: 95.5 nM
Compound 4: middle estimate off by 1.6-fold (0.20 log units), on the high side; the measured number falls inside the stated range.
By their numbers in this assay, from the lowest: compounds 1 and 4 (each within the scatter of the next); then compound 2; then compound 3.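

In this assay, a substituted ring at this position is no longer tied to a higher number: hydroxy in place of hydrogen gives a 1.3-fold higher number from compound 1 to compound 4 (0.10 log units; within the scatter), so the first substituent to leave the number within the scatter of the unsubstituted ring is the one in 2-hydroxyphenyl. The 2-hydroxyphenyl group also stands clear of both other substituted rings, with a 6.6-fold lower number from compound 3 to compound 4 (0.82 log units; beyond the scatter) against 4-methylphenyl and a 3.2-fold lower number from compound 2 to compound 4 (0.50 log units; beyond the scatter) against 4-methoxyphenyl, so the rise seen with those two groups does not extend to every substituent on this ring. No measurements on how these compounds behave are available to explain these differences.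

The change from 4-methylphenyl to 2-hydroxyphenyl alters both the substituent and its place on the ring, so these four compounds cannot separate the two contributions; 2-methylphenyl and 4-hydroxyphenyl groups would be the direct tests. From the compounds shown here alone, it also remains open whether the result is particular to hydroxy or would hold for another group on the ring, such as an amine or a fluorine atom, in the same place.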